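Replacing tert-butyl with chloro: an expected growth-inhibition gain

The source may report more compounds than this note shows. Statements on the series, on what has been measured and on what is new or still open speak of the compounds shown alone.

Measured in a functional assay on A-375 cells (Homo sapiens) for inhibition, read by CCK-8 assay, with a stated time of 72 h, tested at 8 uM; on this read-out higher numbers stand for more inhibition of growth at the one concentration tested and lower numbers for less inhibition of growth:
- compound 1 `CCc1ccc(SCc2ccc(C(=O)Nc3ccccc3N)cc2)cc1`: 71.1%
- compound 2 `Nc1ccccc1NC(=O)/C=C/c1ccc(CSc2ccc(F)cc2)cc1`: 24.6%
- compound 3 `CC(C)(C)c1ccc(SCc2ccc(C(=O)Nc3ccccc3N)cc2)cc1`: 33.1%

Compound 3, at 33.1%, lies within the scatter of compound 2 and well under compound 1. The next compound to consider is compound 4 `Nc1ccccc1NC(=O)c1ccc(CSc2ccc(Cl)cc2)cc1`, which has not yet been measured in this assay. It has chloro in place of tert-butyl on an aromatic carbon, para to a large group: chloro in place of tert-butyl on an aromatic carbon.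

Within the data shown here, one measured step bears on this change: a number 38 percentage points lower from compound 1 to compound 3 (beyond the scatter), a large step that came with tert-butyl in place of ethyl on an aromatic carbon. Compound 2 differs from the others in more than one place, so it gives no clean comparison. Among the measured compounds shown here, no measured compound carries chloro, so the size of the step remains uncertain. Removing tert-butyl may recover much of the large loss seen in compound 3, so a rise beyond the scatter is expected. The expected change is a number 24.9 percentage points higher from compound 3 to compound 4 (beyond the scatter).

For compound 4 the estimated value is 58%, with an expected range from 33% to 82%.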

Compound 4, percent growth inhibition at one concentration: 48.6%
Compound 4: middle estimate off by 9.4 percentage points, on the high side; measured number inside the range.
By their numbers in this assay, from the lowest: compounds 2 and 3 (each within the scatter of the next); then compound 4; then compound 1.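

At this position on the aromatic ring, para to a large group, the three compounds sharing one core now allow ethyl, chloro and tert-butyl to be compared in this assay, and chloro in place of tert-butyl gives a number 15.5 percentage points higher from compound 3 to compound 4 (beyond the scatter). Chloro does not match ethyl, however, with a number 22.5 percentage points lower from compound 1 to compound 4 (beyond the scatter), so in this set, the much smaller chloro only partly restores what is lost with tert-butyl, and having fewer heavy atoms than tert-butyl does not by itself bring a group up to the level of ethyl. Nothing measured here explains this order.

The compounds shown leave open how a methoxy group, an amine or a longer chain at this position would compare with ethyl and chloro. They also leave open whether the same order would hold on the core of compound 2.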